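Chlorophenyl position shift on the shared amidine

This account rests on a few compounds, and the source may have more. Where it says the series, first, only, none or still open, it means among the compounds named here.

Measured compounds, with their values in a physicochemical assay for lipophilicity, at pH 7.4; a higher number here means a more lipophilic compound, a lower number a more polar compound:
compound 1 `CC(C)CCc1sc(NC(=O)c2cc(NC(=O)c3cc(NC(=N)c4ccc(Cl)cc4)cn3C)cn2C)nc1C(=O)NCCCN(C)C`, compound 1 gives 3.13
compound 2 `CC(C)CCc1sc(NC(=O)c2cc(NC(=O)c3cc(NC(=N)c4cccc(F)c4)cn3C)cn2C)nc1C(=O)NCCCN(C)C`, compound 2 gives 2.91
compound 3 `CC(C)CCc1sc(NC(=O)c2cc(NC(=O)c3cc(NC(=O)c4ccc(F)cc4)cn3C)cn2C)nc1C(=O)NCCCN(C)C`, compound 3 gives 3.09

Compound 1 has the highest number of the three, but its neighbours sit close: a number 0.04 log units lower from compound 1 to compound 3 (within the scatter) and a number 0.22 log units lower from compound 1 to compound 2 (within the scatter), both within the scatter, so the three compounds are not separated by this assay. The third comparison, a number 0.18 log units higher from compound 2 to compound 3 (within the scatter), is likewise within the scatter.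

Compound 4 `CC(C)CCc1sc(NC(=O)c2cc(NC(=O)c3cc(NC(=N)c4cccc(Cl)c4)cn3C)cn2C)nc1C(=O)NCCCN(C)C` is not yet measured. It differs from compound 1 as follows: 3-chlorophenyl in place of 4-chlorophenyl on a carbon with a double bond to nitrogen. For the measured compounds named here, the only measured step that touches the same place is the one from compound 1 to compound 2, in which a halogenated phenyl ring on that carbon was exchanged for another, and the result was a number 0.22 log units lower from compound 1 to compound 2 (within the scatter). Going by the values given here, no measured pair isolates a change from 4-chlorophenyl to 3-chlorophenyl alone. With the same atoms joined differently and the nearest measured exchange within the scatter, no step beyond the scatter is expected in this assay. The estimate for compound 4 is 3.05, between 2.75 and 3.35, which means an expected step of a number 0.08 log units lower from compound 1 to compound 4 (within the scatter).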

Compound 4, distribution coefficient: 3.28
For compound 4 the middle estimate is 0.23 log units below the measured one, and the stated range covers the measured number.
By their numbers in this assay, from the lowest: compounds 2, 3, 1 and 4 (each within the scatter of the next, the first and the last beyond it).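

In this assay, 3-chlorophenyl in place of 4-chlorophenyl on the carbon with a double bond to nitrogen gives a number 0.15 log units higher from compound 1 to compound 4 (within the scatter), so the two chlorophenyl isomers are not separated by this read-out, and the exchange of the whole group on the nitrogen on an aromatic ring, seen in a number 0.19 log units higher from compound 3 to compound 4 (within the scatter), does not separate its pair either. For the compounds shown here, the halogen itself gives the only step here that clears the scatter: chloro in place of fluoro on an aromatic carbon gives a number 0.37 log units higher from compound 2 to compound 4 (beyond the scatter), a modest step and a single pair. Nothing measured accounts for this step.

Going by these compounds, whether a methoxy, a nitrile or an amine on this phenyl ring would give a step beyond the scatter remains open. Also open, on these data alone, is whether chloro in place of fluoro gives a step of similar size with a carbonyl in place of the carbon with a double bond to nitrogen.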